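Swapping a Pyridinyloxy Group for a Methylthiazole

This account rests on a few compounds, and the source may have more. Where it says the series, first, only, none or still open, it means among the compounds named here.

Measured so far, in an ADME assay on PC-3 cells (Homo sapiens) for cytotoxicity, read by WST assay, tested at 100 uM; a lower number here means less inhibition, a higher number more inhibition at the concentration tested (going by the name of the read-out):
compound 1 `O=C(Nc1cccc(Oc2ccccn2)c1)C1CCCN(C(=O)c2cc(C(F)(F)F)cc(C(F)(F)F)c2)C1` gives 0%
compound 2 `COCc1cccc(C(=O)N2CCCC(C(=O)Nc3ccc(Cl)cc3)C2)c1` gives 0%
compound 3 `Cc1nc(-c2cccc(C(=O)N3CCCC(C(=O)Nc4ccc(Cl)cc4)C3)c2)cs1` gives 1%

Compound 1 stands level with compound 2 at the digits shown, and compound 3 lies within the scatter of both, so the three numbers are indistinguishable. Compound 4 `Cc1nc(-c2cccc(NC(=O)C3CCCN(C(=O)c4cc(C(F)(F)F)cc(C(F)(F)F)c4)C3)c2)cs1` differs from compound 1 in one place: 2-methyl-1,3-thiazol-4-yl in place of (pyridin-2-yl)oxy on an aromatic carbon. Going by the values given here, one measured step bears on this change, a number 1 percentage points higher from compound 2 to compound 3 (within the scatter), which brings in the same 2-methyl-1,3-thiazol-4-yl group, though there it displaces methoxymethyl rather than (pyridin-2-yl)oxy. Because a number 1 percentage points higher from compound 2 to compound 3 (within the scatter) stays within the scatter, no step beyond the scatter is expected in this assay, that is, an expected a number 1 percentage points higher from compound 1 to compound 4 (within the scatter). Compound 4 is therefore estimated at 1%, with a range from 0% to 12%.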

Compound 4, a percentage reported as inhibition, at one concentration (the size of the read-out at that concentration, not a potency): 1%
The estimate for compound 4 equals the measured number at the digits printed; low and high end bracket the measured number.
By their numbers in this assay, from the lowest: compounds 1, 2, 3 and 4 (each within the scatter of the next).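

In this assay, putting 2-methyl-1,3-thiazol-4-yl in place of (pyridin-2-yl)oxy gives a number 1 percentage points higher from compound 1 to compound 4 (within the scatter). The earlier step brought this group in for methoxymethyl on a different compound, whereas this one shows the same result in the compound carrying two trifluoromethyl groups and with a different group leaving. No available measurement explains this result.

As far as these compounds go, all four readings lie within the scatter of one another, so it remains open whether any group at this place can shift the reading. An amine or a carboxylic acid there would be one test.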